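The compounds below may be only part of what the source reports. "The series", "measured", "known", "first", "only" and "open" are said of these compounds alone.

Compound 2 `O=C(OCCOCN1c2ccccc2C(=O)N(Cc2ccccc2)S1(=O)=O)c1ccccc1` stands at the higher of the two numbers recorded in a functional assay on CCRF-CEM cells (Homo sapiens) for cytotoxicity; on this read-out higher numbers stand for lower toxicity in this test and lower numbers for higher toxicity in this test; compound 2 gives 100 ug/mL. Its nearest neighbour is compound 1 `O=C1c2ccccc2N(COCCO)S(=O)(=O)N1Cc1ccccc1`, in which the chain ends in a free hydroxyl; in this assay compound 1 gives 89 ug/mL. Within the data shown here, the only step among the measured pair, a 1.1-fold higher number from compound 1 to compound 2 (0.05 log units; within the scatter), therefore shows that capping the terminal oxygen with benzoyl changed nothing that rises above the scatter of this test.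

Compound 3 `C#CCOCN1c2ccccc2C(=O)N(Cc2ccccc2)S1(=O)=O` has not yet been measured. It differs from compound 2 in a single place: ethynyl in place of (benzoyloxy)methyl on a saturated chain carbon bound to an oxygen on a saturated carbon. Among the measured compounds shown here, no measured step covers this change directly; the one step that exists concerns the other end of the same chain and was flat. The shared core, the benzyl group and the oxymethyl linkage on the ring nitrogen are untouched, and the core itself has so far shown only weak cytotoxicity regardless of what hangs on that chain.

On this basis compound 3 is expected to remain in the same weakly cytotoxic region, so that a 1.1-fold lower number from compound 2 to compound 3 (0.05 log units; within the scatter) is the estimated step. Compound 3 is thus estimated at 90 ug/mL in this assay, with a range from 40 ug/mL to 200 ug/mL.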

Compound 3, half-maximal cytotoxic concentration: 23 ug/mL
For compound 3 the middle estimate is 3.9-fold (0.59 log units) above the measured one; measured number below the stated range.
By their numbers in this assay, from the lowest: compound 3; then compounds 1 and 2 (each within the scatter of the next).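

The change at this position does move the number in this assay: ethynyl in place of (benzoyloxy)methyl on a saturated chain carbon bound to an oxygen on a saturated carbon gives a 4.3-fold lower number from compound 2 to compound 3 (0.64 log units; beyond the scatter), and ethynyl in place of hydroxymethyl at the same place gives a 3.9-fold lower number from compound 1 to compound 3 (0.59 log units; beyond the scatter). The flat step seen earlier had therefore shown only that the end of this chain tolerates a benzoyl cap, not that the shared core sets the number whatever the chain carries, and compound 3, with its propargyl group, now stands as the most toxic of the three in this test. Nothing available here bears on what lies behind this drop.

The replacement removes a whole chain end and brings in a triple bond in one move, so the compounds shown do not separate the two, and it remains open whether a saturated propyl chain, an allyl group or a but-2-ynyl group would give a number like that of compound 3. As far as these compounds go, whether an amine or a carboxylic acid at the end of the chain would move the number in either direction also stays open.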